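Hydroxy on the ring carbon of the inactive series

The compounds below may be only part of what the source reports. "The series", "measured", "known", "first", "only" and "open" are said of these compounds alone.

Measured in a functional assay on MEL28 cells (Homo sapiens) for cytotoxicity, read by sulforhodamine B assay, with a stated time of 72 h; on this read-out lower numbers stand for stronger inhibition of growth and higher numbers for weaker inhibition of growth:
- compound 1 `C=C1CC[C@@H]2[C@](C)(CCC[C@]2(C)C(=O)OC)[C@H]1CCc1ccc2c(OCc3ccccc3)ccc(OCc3ccccc3)c2c1`: > 5000 nM (a limit)
- compound 2 `C=C1CC[C@@H]2[C@](C)(CCC[C@]2(C)C(=O)OCc2ccccc2)[C@H]1CCc1ccc2c(OCc3ccccc3)ccc(OCc3ccccc3)c2c1`: "not determined" (no result reported) (no result reported)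
- compound 3 `C=C1[C@H](O)C[C@@H]2[C@](C)(CCC[C@]2(C)C(=O)OC)[C@H]1CCc1ccc2c(OCc3ccccc3)ccc(OCc3ccccc3)c2c1`: > 4900 nM (a limit)

In this assay compound 1 gives > 5000 nM, which is a limit and not a number. Compound 3 gives > 4900 nM, which is also a limit. Among the compounds with values here, compound 1 therefore has no numerical position, and no measured compound here provides a numerical reference.

Compound 4 `C=C1CC[C@@H]2[C@](C)(CCC[C@]2(C)C(=O)OC)[C@]1(O)CCc1ccc2c(OCc3ccccc3)ccc(OCc3ccccc3)c2c1` is the next compound to be read. It differs from compound 1 by a single change: hydroxy in place of hydrogen on a saturated ring carbon. Within the data shown here, one measured step bears on this change: a step that the two limits leave unreadable from compound 1 to compound 3. That step is also hydroxy in place of hydrogen on a saturated ring carbon, but at a different ring carbon of the core. Its size cannot be read, so it offers no direction for compound 4. It does show that compound 3, with > 4900 nM, remains a limit after that exchange.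

The estimated step is a number no higher from compound 1 to compound 4 (the limit leaves the size open), and no shift beyond the scatter is expected in this assay. The expected value for compound 4 is 5000 nM, with an estimated range of 2000 nM to 8000 nM.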

Compound 4, concentration for 50% growth inhibition: 9000 nM
Compound 4: middle estimate off by 1.8-fold (0.26 log units), on the low side; measured number outside the range, above it.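

In this assay compound 1 gives > 5000 nM, which is a limit. Compound 4 gives 9000 nM, so the step between compound 1 and compound 4 cannot be read. The compounds shown leave open whether hydroxy in place of hydrogen on a saturated ring carbon shifts growth inhibition in either direction.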